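Cyclopropyl to phenyl at the amide-bearing carbon: compound 3

The source may report more compounds than this note shows. Statements on the series, on what has been measured and on what is new or still open speak of the compounds shown alone.

In a functional assay on MM1 cells (Homo sapiens) for antiproliferative activity, read by MTT assay, with a stated time of 72 h (on this read-out lower numbers stand for stronger inhibition and higher numbers for weaker inhibition), compound 1 `N#C/C(=C\c1cccc(Br)n1)C(=O)NC(c1ccccc1)C1CC1` gives 1100 nM. Compound 2 `N#C/C(=C\c1cccc(Br)n1)C(=O)N[C@H](c1ccccc1)C1CC1`, the same framework with the stereocentre drawn as S, gives 1400 nM in this assay, and a 1.3-fold higher number from compound 1 to compound 2 (0.10 log units; within the scatter). Compound 3 `N#C/C(=C\c1cccc(Br)n1)C(=O)NC(c1ccccc1)c1ccccc1` differs from compound 1 by phenyl in place of cyclopropyl on a saturated chain carbon bound to an amide-type nitrogen and an aromatic carbon. Among the measured compounds shown here, no measured step exchanges these two groups; the single measured step rests only on the fact that one of compounds 1 and 2 is drawn with a defined configuration and the other without, at the place where they differ and stays within the scatter, so it says nothing about this replacement. For compound 3 the step in this assay is expected as a 1.4-fold higher number from compound 1 to compound 3 (0.13 log units; within the scatter), with no firm direction. Compound 3 is estimated at 1500 nM, expected between 450 nM and 5000 nM.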

Compound 3, half-maximal inhibitory concentration: 5000 nM
Compound 3: the middle estimate sits 3.3-fold (0.52 log units) below what was measured, and the stated range covers the measured number.
By their numbers in this assay, from the lowest: compounds 1 and 2 (each within the scatter of the next); then compound 3.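

In this assay, the group on the saturated chain carbon bound to an amide-type nitrogen and an aromatic carbon does matter: phenyl in place of cyclopropyl comes with a 4.5-fold higher number from compound 1 to compound 3 (0.66 log units; beyond the scatter) in this series. Compound 1 and compound 2 differ only in how a stereocentre is drawn, so they gave no reading of the group itself. No evidence at hand bears on this replacement.

Open, as far as these compounds go, is whether an isopropyl group or a longer chain such as n-butyl at this carbon would track compound 1 or compound 3. From the compounds shown here alone, the effect of an amine or a carboxylic acid on that phenyl or cyclopropyl group is equally open.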